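This account rests on a few compounds, and the source may have more. Where it says the series, first, only, none or still open, it means among the compounds named here.

In a functional assay on MCF7 cells (Homo sapiens) for antiproliferative activity, read by MTT assay, with a stated time of 72 h (on this read-out higher numbers stand for weaker inhibition and lower numbers for stronger inhibition), compound 2 `CC1=CC[C@H]2[C@H](CC[C@]2(C)O)C(C)(C)[C@@H]1CC[C@H]1[C@]2(C)CC[C@H](OC(=O)c3ccc([N+](=O)[O-])cc3)C(C)(C)O[C@H]2CC[C@@]1(C)O` gives 21600 nM, which sits within the scatter of compound 1 `CC1=CC[C@H]2[C@H](CC[C@]2(C)O)C(C)(C)[C@@H]1CC[C@H]1[C@]2(C)CC[C@H](OC(=O)c3ccncc3)C(C)(C)O[C@H]2CC[C@@]1(C)O` at 25300 nM. Compound 3 `CC1=CC[C@H]2[C@H](CC[C@]2(C)O)C(C)(C)[C@@H]1CC[C@H]1[C@]2(C)CC[C@H](OC(=O)c3ccc(C(F)(F)F)cc3)C(C)(C)O[C@H]2CC[C@@]1(C)O` keeps the shared core and changes one group, with trifluoromethyl in place of nitro on an aromatic carbon. Among the measured compounds shown here, the only measured step that bears on this is a 1.2-fold lower number from compound 1 to compound 2 (0.07 log units; within the scatter). It also changed the group on that aromatic side and stayed within the scatter, so no step beyond the scatter is expected in this assay. The expected step is a 1.0-fold higher number from compound 2 to compound 3 (0.01 log units; within the scatter). Compound 3 is estimated at 22000 nM, with an expected range from 12000 nM to 40000 nM.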

Compound 3, half-maximal inhibitory concentration: 23400 nM
Estimate against measurement, compound 3: 1.1-fold (0.03 log units) below; measured number inside the range.
By their numbers in this assay, from the lowest: compounds 2, 3 and 1 (each within the scatter of the next).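

In this assay the step of a 1.1-fold higher number from compound 2 to compound 3 (0.03 log units; within the scatter) shows that the hydrogen-bond acceptors of nitro can leave this aromatic carbon with no change beyond the scatter. The step of a 1.1-fold lower number from compound 1 to compound 3 (0.03 log units; within the scatter) for 4-(trifluoromethyl)phenyl in place of pyridin-4-yl on the carbonyl carbon places all three groups within the scatter of each other. No measured evidence here explains this flat result. Still open, going by these compounds, is whether an amine or a carboxylic acid on this aromatic carbon, or a longer chain on the carbonyl carbon, would move the number beyond the scatter.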